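The source may report more compounds than this note shows. Statements on the series, on what has been measured and on what is new or still open speak of the compounds shown alone.

Two compounds have a result in an ADME assay on THP-1 cells (Homo sapiens) for cytotoxicity (a higher number here means that more compound is tolerated, a lower number that less compound is tolerated), and one more awaits it. Compound 1, `c1ccc(-c2nc3ccccn3c2NC2CCOC2)nc1`, is one of them. In this assay compound 1 reaches only a limit, > 50000 nM, and no number was obtained. Compound 2, `c1ccc(Nc2c(-c3ccccn3)nc3ccccn23)cc1`, gives 6690 nM in this assay. So compound 2 holds the only real number among the values shown, with the other value being a limit, which is how compound 1 comes to sit at the limit of > 50000 nM in this assay, at which 1 of the 2 values shown sits. Among the compounds with values here, the one measured step, an at least 7.4-fold lower number from compound 1 to compound 2 (0.87 log units; beyond the scatter), ends at this limit and therefore tells only how large the change was at least, not how large it truly was.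

Compound 3, `FC(F)(F)Oc1ccc(Nc2c(-c3ccccn3)nc3ccccn23)cc1`, is not yet measured. It differs from compound 2 by trifluoromethoxy in place of hydrogen on an aromatic carbon. No measured step here alters that part of the structure, so the one step shown, which changed the group on the nitrogen, does not speak directly to this change. With no guide of that kind, compound 3 is expected to sit close to compound 2, with a 1.3-fold lower number from compound 2 to compound 3 (0.13 log units; within the scatter) as the estimated step. Compound 3 is thus estimated at 5000 nM, expected to lie between 1800 nM and 14000 nM.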

Compound 3, half-maximal cytotoxic concentration: > 50000 nM
Compound 3 ended at the assay's limit; the forecaster's own chance of this, stated with the estimate: 5%; middle value at least 10-fold (1.00 log units) from the limit.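

The earlier step changed only the group on the nitrogen, so it said nothing about the phenyl ring of compound 2 itself. In this assay, trifluoromethoxy in place of hydrogen on an aromatic carbon, para to a large group, gives an at least 7.4-fold higher number from compound 2 to compound 3 (0.87 log units; beyond the scatter), which shows that this ring position matters and that keeping a substituted phenyl on the nitrogen does not by itself bring a measurable number. Compound 3 reaches only a limit, so this step gives a minimum size and not the true size, and the set now stands as follows: the limit of > 50000 nM in this assay, at which 2 of the 3 values shown sit.

On these data alone, it remains open whether this change is particular to trifluoromethoxy, or whether a methoxy group, a chlorine atom or an amine on the same aromatic carbon would also move the number in this assay in this direction. As far as these compounds go, how much more compound is tolerated for compound 3 than the limit can express also remains open, and so does any ordering among the compounds that sit at that limit.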